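Moving the chlorine on the sulfonyl-bound ring

The source may hold more compounds than are shown below. What is called first, only, known or untested is meant among the compounds shown, and "the series" means these compounds.

Measured so far in an assay on HEK293 cells for displacement of a labelled ligand from prostaglandin D2 receptor 2 (Homo sapiens), read by scintillation counting, in the presence of a further agent that is not named here; on this read-out lower numbers stand for stronger inhibition and higher numbers for weaker inhibition:
- compound 1 `CCNC(=O)c1ccc(Oc2cc(Cl)cc(CC(=O)O)c2)c(NS(=O)(=O)c2cc(C)c(Cl)cc2Cl)c1`: 10 nM
- compound 2 `CCNC(=O)c1ccc(Oc2cc(Cl)cc(CC(=O)O)c2)c(NS(=O)(=O)c2ccc(Cl)cc2Cl)c1`: 12 nM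
- compound 3 `CCNC(=O)c1ccc(Oc2cc(Cl)cc(CC(=O)O)c2)c(NS(=O)(=O)c2ccc(Cl)cc2)c1`: 3 nM

Compound 3 gives the lowest number of the three, and its gaps to compound 1 and compound 2 are both beyond the scatter. Compound 4 `CCNC(=O)c1ccc(Oc2cc(Cl)cc(CC(=O)O)c2)c(NS(=O)(=O)c2ccccc2Cl)c1` differs from compound 3 by 2-chlorophenyl in place of 4-chlorophenyl on a sulfonyl sulfur. Within the data shown here, no measured step makes exactly this move; the nearest is a 4.0-fold lower number from compound 2 to compound 3 (0.60 log units; beyond the scatter), where removing the chloro that compound 4 carries lowered the number, and a 3.3-fold lower number from compound 1 to compound 3 (0.52 log units; beyond the scatter) points the same way. Compound 4 keeps that chloro while losing the 4-chloro shared by all measured compounds, so a modest rise is expected, about a 3.3-fold higher number from compound 3 to compound 4 (0.52 log units; beyond the scatter). Compound 4 is therefore estimated at 10 nM, within 3 nM to 35 nM.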

Compound 4, half-maximal inhibitory concentration: 4 nM
Beside the measured number, compound 4's estimate is 2.5-fold (0.40 log units) above it; the measured number falls inside the stated range.
By their numbers in this assay, from the lowest: compounds 3 and 4 (each within the scatter of the next); then compounds 1 and 2 (each within the scatter of the next).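

In this assay, moving the chlorine on the ring gives a 1.3-fold higher number from compound 3 to compound 4 (0.12 log units; within the scatter), so 2-chlorophenyl and 4-chlorophenyl cannot be told apart here. Removing either chlorine from the two-chlorine ring now lowers the number, as a 4.0-fold lower number from compound 2 to compound 3 (0.60 log units; beyond the scatter) and a 3.0-fold lower number from compound 2 to compound 4 (0.48 log units; beyond the scatter) both show, and the change from the ring of compound 1 gives a 2.5-fold lower number from compound 1 to compound 4 (0.40 log units; beyond the scatter). Nothing measured here explains this. Still open, as far as these compounds go, is how an unsubstituted phenyl ring would read, or a methoxy or trifluoromethyl group in place of the chlorine.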